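The compounds below may be only part of what the source reports. "The series", "measured", "known", "first", "only" and "open" are said of these compounds alone.

Measured so far:
- compound 1 `Nc1cc(N)c2nc(-c3ccccc3)c(Oc3ccc(Cl)c(Cl)c3)nc2c1` gives 9770 nM
- compound 2 `Nc1cc(N)c2nc(-c3ccccc3)c(NCc3ccc(Cl)c(Cl)c3)nc2c1` gives 3470 nM
- compound 3 `CCOC(=O)[C@H](CCC(=O)O)NC(=O)c1ccc(Sc2nc3cc(N)cc(N)c3nc2-c2ccccc2)cc1` gives 12600 nM

These values come from a functional assay on SK-MEL-5 cells (Homo sapiens) for inhibition, read by sulforhodamine B assay, with a stated time of 48 h; on this read-out higher numbers stand for weaker inhibition of growth and lower numbers for stronger inhibition of growth. Compound 1 has the second highest of the three numbers. Its nearest neighbour is compound 3, whose number lies within the usual scatter of that of compound 1. Compound 2 sits further away, with a lower number that lies beyond the scatter relative to compound 1.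

The step under consideration leads from compound 1 to compound 4 `Nc1cc(N)c2nc(-c3ccccc3)c(Sc3ccc(F)cc3)nc2c1`. The change is (4-fluorophenyl)sulfanyl in place of 3,4-dichlorophenoxy on an aromatic carbon. Both the group that leaves and the group that enters carry a single aromatic ring of carbon only and a single hydrogen-bond acceptor; the leaving group is the larger of the two by one heavy atom.

Among the compounds with values here, no measured pair shares this change, so there is no measured step to lean on. Given that compound 3, which also carries a sulfur-linked aromatic group at this position, returns 12600 nM, a number within the scatter of compound 1, the expectation for the step is one of no movement beyond the scatter, in either direction. The step is estimated as a 1.1-fold lower number from compound 1 to compound 4 (0.04 log units; within the scatter). For compound 4 in this assay the estimate is 9000 nM, with a range from 3500 nM to 25000 nM.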

Compound 4, concentration for 50% growth inhibition: 15500 nM
Beside the measured number, compound 4's estimate is 1.7-fold (0.24 log units) below it, and the stated range covers the measured number.
By their numbers in this assay, from the lowest: compound 2; then compounds 1, 3 and 4 (each within the scatter of the next).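

In this assay, the first step readable at this aromatic carbon runs a 1.6-fold higher number from compound 1 to compound 4 (0.20 log units; within the scatter) and exchanges 3,4-dichlorophenoxy for (4-fluorophenyl)sulfanyl. The oxygen link and the two chlorines thus give way to a sulfur link and one fluorine with no movement beyond the scatter, although this one step cannot separate the two alterations. No measurement shown bears on what lies behind this outcome.

Open, from the compounds shown here alone, is how far the link and the ring substituents each count, which (3,4-dichlorophenyl)sulfanyl or 4-fluorophenoxy at the same carbon would help to separate. Also open, going by these compounds, is whether a group without an aromatic ring, such as a piperazine or a simple alkyl chain, would shift the number beyond the scatter at this position.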